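Acetamidoethyl to carboxy-hydroxypropyl on the amine nitrogen

A few compounds are considered here, and "the series" means these few. Any claim that something is new, unique, unknown or untested is made for them only; others in the source may bear on it.

Among the compounds with values here, in a functional assay on B16-F10 cells (Mus musculus) for antiproliferative activity, read by CCK-8 assay, with a stated time of 48 h (a lower number here means a stronger inhibitor, a higher number a weaker inhibitor), compound 3 `COc1ccc(/C=C\c2cc(OC)c(OC)c(OC)c2)cc1OCc1ccc(CNCCNC(C)=O)cc1` gives 2500 nM, the only true number so far. Compound 1 `COc1ccc(/C=C\c2cc(OC)c(OC)c(OC)c2)cc1OCc1ccc(CN[C@H](C(=O)O)[C@H](C)O)cc1` reads > 10000 nM, which is a limit of the assay and not a number. Compound 2 `COc1ccc(/C=C\c2cc(OC)c(OC)c(OC)c2)cc1OCc1ccc(CN2CC[C@H](O)C2)cc1` reads > 10000 nM, again only a limit. The comparison therefore rests on (the limit of > 10000 nM in this assay, at which 2 of the 3 values shown sit).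

Compound 4 `COc1ccc(/C=C\c2cc(OC)c(OC)c(OC)c2)cc1OCc1ccc(CN[C@H](C(=O)O)[C@@H](C)O)cc1` departs from compound 3 in one place: 1-carboxy-2-hydroxypropyl in place of 2-acetamidoethyl on an amine nitrogen. In words, 1-carboxy-2-hydroxypropyl stands in place of 2-acetamidoethyl on an amine nitrogen. Compound 1 carries a group of the same name, and the nearest measured evidence is an at least 4.0-fold lower number from compound 1 to compound 3 (0.60 log units; beyond the scatter), the same exchange run in the opposite direction. A second step, an at least 4.0-fold lower number from compound 2 to compound 3 (0.60 log units; beyond the scatter), also favours compound 3, but it changes more of the amine. Both sizes are bounded by a limit, so they are minimums.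

A step of similar size toward a higher, weaker number is therefore expected in this assay, and the estimated step is a 4.8-fold higher number from compound 3 to compound 4 (0.68 log units; beyond the scatter). Compound 4 is expected at about 12000 nM, with an estimated range of 5000 nM to 30000 nM.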

Compound 4, half-maximal inhibitory concentration: 5400 nM
For compound 4 the middle estimate is 2.2-fold (0.35 log units) above the measured one, and the stated range covers the measured number.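

The 1-carboxy-2-hydroxypropyl group on the amine nitrogen can therefore give a true number in this assay, which compound 1 alone could not show. Set against 2-acetamidoethyl, this group costs only a modest step, a 2.2-fold higher number from compound 3 to compound 4 (0.33 log units; beyond the scatter). The other two steps, an at least 1.8-fold lower number from compound 1 to compound 4 (0.26 log units; that floor lies within the scatter) and an at least 1.8-fold lower number from compound 2 to compound 4 (0.26 log units; that floor lies within the scatter), are minimums set by an assay limit, so neither gives a true size, and the first of them concerns a pair with a single difference: the fact that compounds 1 and 4 differ only in the configuration as drawn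

On these data alone, how far compound 1 truly lies from compound 4 remains open, so the size of this configuration effect cannot be stated. Also open, as far as these compounds go, is whether a methyl ester in place of the carboxylic acid, or a longer chain on the amine nitrogen, would move the number in this assay.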